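The compounds below may be only part of what the source reports. "The series", "measured", "known", "first", "only" and "open" are said of these compounds alone.

Compound 1 `CC(C)c1ccc(-c2nc3sccn3c2/C=N/OCc2ccc(Cl)c(Cl)c2)cc1` gives 590 nM in an assay on HepG2 cells for agonist activity at nuclear receptor subfamily 1 group I member 3 (Homo sapiens), read by a luciferase reporter, with a stated time of 23 h; a lower number here means that less compound is needed, a higher number that more compound is needed for the effect. For the measured compounds named here, of the two numbers so far it is the higher one, but its only neighbour, compound 2 `Clc1ccc(CO/N=C/c2c(-c3ccc4ccccc4c3)nc3sccn23)cc1Cl` at 380 nM, sits within the scatter: a 1.6-fold lower number from compound 1 to compound 2 (0.19 log units; within the scatter). Compound 3 `Clc1ccc(CO/N=C/c2c(-c3ccc(C4CCCCC4)cc3)nc3sccn23)cc1Cl` differs from compound 1 at the same aromatic carbon: cyclohexyl in place of isopropyl on an aromatic carbon. Going by the values given here, the one step that bears on this position, a 1.6-fold lower number from compound 1 to compound 2 (0.19 log units; within the scatter), stayed within the scatter, so no step beyond the scatter is expected in this assay for compound 3, with a 1.3-fold lower number from compound 1 to compound 3 (0.12 log units; within the scatter). Compound 3 is therefore estimated at 450 nM, with a range of 200 nM to 1200 nM.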

Compound 3, half-maximal effective concentration: > 100000 nM
Compound 3 gave a limit, no number (the forecaster's own chance of this, stated with the estimate: 5%); middle value at least 220-fold (2.34 log units) away from the limit.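

In this assay, replacing isopropyl with cyclohexyl para to a large group gives an at least 160-fold higher number from compound 1 to compound 3 (2.22 log units; beyond the scatter), so this position can respond sharply to a single change. The naphthalen-2-yl step had not shown this, having stayed within the scatter. The entry for compound 3 is a limit of the assay and not a number: the limit of > 100000 nM in this assay, at which 1 of the 3 values shown sits.

On these data alone, the actual size of the step therefore stays open. Also open, as far as these compounds go, is where between isopropyl and cyclohexyl the response changes, for which a tert-butyl or cyclopropyl group at this position would be informative.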